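The source may report more compounds than this note shows. Statements on the series, on what has been measured and on what is new or still open speak of the compounds shown alone.

Measured so far:
Compound 1, `O=C(Nc1ccccc1)c1c(O)c2cccnc2n(-c2ccccc2)c1=O`: 4.6%
Compound 2, `O=C(Nc1cccc([N+](=O)[O-])c1)c1c(O)c2cccnc2n(-c2ccccc2)c1=O`: 5.7%

The account follows the step from compound 1 to compound 3. Among the measured compounds shown here, in a functional assay on the whole organism for inhibition, with Rattus norvegicus as the target, read by paw edema, at a dose of 100 mg/kg by the oral route (a lower number here means less inhibition, a higher number more inhibition at the dose given (going by the name of the read-out)), compound 1 gives 4.6%; the only other measured compound, compound 2, gives 5.7%, and the two numbers lie within the scatter of each other, both at the low end of the read-out. For the measured compounds named here, the one measured step, a number 1.1 percentage points higher from compound 1 to compound 2 (within the scatter), tells that a nitro group entering the anilide ring in place of hydrogen left the read-out where it was.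

Compound 3, `COc1ccccc1NC(=O)c1c(O)c2cccnc2n(-c2ccccc2)c1=O`, differs from compound 1 by methoxy in place of hydrogen on an aromatic carbon. Going by the values given here, no measured step carries a methoxy group; the single step that bears on it is the nitro step from compound 1 to compound 2, which stayed within the scatter. On that evidence, a change of a single small group on the same ring is not expected to move the read-out beyond the scatter.

The expected step is therefore a number 1.4 percentage points higher from compound 1 to compound 3 (within the scatter), and compound 3 is estimated to give 6%, within a range from 0% to 18%.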

Compound 3, a percentage reported as inhibition, in the whole organism at one dose (the size of the read-out at that dose, not a potency): 8.1%
For compound 3 the middle estimate is 2.1 percentage points below the measured one, within the range that was stated.
By their numbers in this assay, from the lowest: compounds 1, 2 and 3 (each within the scatter of the next).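

In this assay, methoxy on an aromatic carbon ortho to a large group gives a number 3.5 percentage points higher from compound 1 to compound 3 (within the scatter), so this placement of a second kind of small group on the anilino ring also leaves the read-out within the scatter of the unsubstituted phenyl compound. Exchanging the whole aryl group on the amide-type nitrogen, 2-methoxyphenyl in place of 3-nitrophenyl, gives a number 2.4 percentage points higher from compound 2 to compound 3 (within the scatter), so this change, which differs in both the group and its place on the ring, does not separate the two compounds either. The data offer no explanation for the absence of a separation among the three compounds.

From the compounds shown here alone, it remains open whether any group on this ring can carry the read-out beyond the scatter, for instance an amine, a carboxylic acid, or a longer chain such as butoxy in place of methoxy. Also open, going by these compounds, is whether methoxy would give the same result on another carbon of the ring, and whether changes elsewhere on the shared core would matter more than those on the anilino ring.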